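The source may hold more compounds than are shown below. What is called first, only, known or untested is meant among the compounds shown, and "the series" means these compounds.

Compound 1 `CCCC[C@@H]1O[C@H](COCc2ccccc2)[C@@H](OCc2ccccc2)[C@H](OCc2ccccc2)[C@H]1O` comes out as "not active" (no number reported) in a functional assay on HL-60 cells (Homo sapiens) for antiproliferative activity, read by MTT assay; a higher number here means a weaker inhibitor, a lower number a stronger inhibitor. Going by the values given here, compound 2 `OCCC[C@@H]1O[C@H](COCc2ccccc2)[C@@H](OCc2ccccc2)[C@H](OCc2ccccc2)[C@H]1O` is the only compound with a number in this assay, where compound 2 gives 19300 nM. Compound 3 `O[C@@H]1[C@@H](OCc2ccccc2)[C@H](OCc2ccccc2)[C@@H](COCc2ccccc2)O[C@H]1CC1CC1` differs from compound 2 by cyclopropyl in place of 2-hydroxyethyl on a saturated chain carbon bound to a saturated ring carbon. Since compound 1, which also lacks the hydroxyl, shows "not active" (no number reported), compound 3 is expected to be weaker, and the expected step of a 2.3-fold higher number from compound 2 to compound 3 (0.37 log units; beyond the scatter) is estimated to lie beyond the usual scatter. For compound 3 the estimate in this assay is 45000 nM, with a likely range from 15000 nM to 150000 nM.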

Compound 3, half-maximal inhibitory concentration: "not active" (no number reported)
No number was reported for compound 3, and the estimate cannot be compared.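

In this assay, going by these compounds alone, compound 3 gives "not active" (no number reported), so no step from compound 2 can be read. Nothing available bears on this result. The compounds shown leave open which groups in this place retain a measurable value.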